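The source may hold more compounds than are shown below. What is called first, only, known or untested is meant among the compounds shown, and "the series" means these compounds.

In a functional assay on the whole organism (strain albino) for inhibition, with Rattus norvegicus as the target, read by paw edema, with stated times of 1 h and 2 h, at a dose of 100 mg/kg by the oral route (on this read-out lower numbers stand for less inhibition and higher numbers for more inhibition at the one dose given (going by the name of the read-out)), compound 1, `N#Cc1c(-c2ccc(Cl)cc2)nc(SCC(=O)Nn2c(COc3ccc(Cl)cc3Cl)nc3ccccc3c2=O)[nH]c1=O`, gives 64.9%, and compound 2, `N#Cc1c(-c2ccc(O)cc2)nc(SCC(=O)Nn2c(COc3ccc(Cl)cc3Cl)nc3ccccc3c2=O)[nH]c1=O`, gives 68.4%. The change between them is hydroxy in place of chloro on an aromatic carbon, and it made a step of a number 3.5 percentage points higher from compound 1 to compound 2 (within the scatter). Compound 3, `N#Cc1c(Nc2ccc(Cl)cc2)nc(SCC(=O)Nn2c(COc3ccc(Cl)cc3Cl)nc3ccccc3c2=O)nc1-c1ccc(O)cc1`, gives 77.2% in this assay; the difference between its core and that of compound 1 is not broken down here. Compound 4, `N#Cc1c(Nc2ccc(O)cc2)nc(SCC(=O)Nn2c(COc3ccc(Cl)cc3Cl)nc3ccccc3c2=O)nc1-c1ccc(O)cc1`, has not yet been measured. Its change from compound 3 is hydroxy in place of chloro on an aromatic carbon, the same change as from compound 1 to compound 2. Resting on compound 3 at 77.2% and on the earlier step of a number 3.5 percentage points higher from compound 1 to compound 2 (within the scatter), the expected step is a number 2.8 percentage points higher from compound 3 to compound 4 (within the scatter). Compound 4 is therefore estimated to give about 80% in this assay, expected between 70% and 90%.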

Compound 4, a percentage reported as inhibition, in the whole organism at one dose (the size of the read-out at that dose, not a potency): 86.8%
Compound 4: middle estimate off by 6.8 percentage points, on the low side; the range from low to high includes it.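

In this assay, hydroxy in place of chloro on an aromatic carbon made a step of a number 9.6 percentage points higher from compound 3 to compound 4 (within the scatter). Set beside the earlier step, the change carries from one core to the other with no difference that can be told apart: the same change on two cores in this assay, a number 3.5 percentage points higher (within the scatter) from compound 1 to compound 2 and a number 9.6 percentage points higher (within the scatter) from compound 3 to compound 4, 6.1 percentage points apart, within the scatter of two such steps. Each step lies within the scatter, however, so this does not establish that the change raises the read-out on either core, and two cores say nothing about how it would behave on a third.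

The compounds shown leave open how an amine or a methoxy group at the same place on the ring would compare with hydroxy and chloro.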